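A few compounds are considered here, and "the series" means these few. Any claim that something is new, unique, unknown or untested is made for them only; others in the source may bear on it.

In a functional assay on V79-379A cells (Cricetulus griseus) for cytotoxicity, read by MTT assay, in the presence of a further agent that is not named here (on this read-out lower numbers stand for stronger inhibition and higher numbers for weaker inhibition), compound 1 (`COC1=CC(=O)c2c(c(CO)cn2C)C1=O`) gives 240000 nM and compound 2 (`COC1=CC(=O)c2c(c(COC(=O)c3ccc(F)cc3)cn2C)C1=O`) gives 50 nM on the same read-out. Compound 2 therefore holds the lower of the two numbers and stands for the stronger inhibition, with a gap to compound 1 that lies well beyond the scatter. Compound 3 (`COC1=CC(=O)c2c(c(COC(N)=O)cn2C)C1=O`) has yet to be measured. It differs from compound 2 in a single place, with amino in place of 4-fluorophenyl on a carbonyl carbon. For the measured compounds named here, no measured pair shows what such a swap does, and the expectation rests on just two values. The carbonyl carbon remains in compound 3, which is therefore expected to fall between compound 2 (50 nM) and compound 1 (240000 nM) and nearer the former. The expected change is a 40-fold higher number from compound 2 to compound 3 (1.60 log units; beyond the scatter) towards weaker inhibition and beyond the scatter. Compound 3 is estimated at 2000 nM (expected range 150 nM to 30000 nM).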

Compound 3, half-maximal inhibitory concentration: 40 nM
Estimate against measurement, compound 3: 50-fold (1.70 log units) above; the measured number lies below the stated range.
By their numbers in this assay, from the lowest: compounds 3 and 2 (each within the scatter of the next); then compound 1.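

In this assay amino in place of 4-fluorophenyl on the carbonyl carbon gives a 1.3-fold lower number from compound 2 to compound 3 (0.10 log units; within the scatter) and so shows that, for these two compounds, this place tolerates the loss of the whole six-membered aromatic ring and its fluorine with no change that can be told from scatter. Carbamoyl in place of hydrogen on the oxygen on the saturated carbon gives a 6000-fold lower number from compound 1 to compound 3 (3.78 log units; beyond the scatter) in the same read-out, so the low number seen with compound 2 is now matched by a far smaller group on that oxygen, and the printed values of compound 1 and compound 2 no longer stand alone as the only case of such a gap. No measurement offered here explains why two such different groups give numbers within scatter of each other.

The compounds shown leave open whether the amino nitrogen matters at all, which a methyl on the same carbonyl carbon, giving an acetate, or a dimethylamino group there would begin to answer. They also leave open whether the oxygen on the saturated carbon is needed, a question that an amine or an ether in place of the ester or carbamate oxygen link would address.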